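Extending the aryl ether chain of an amide-linked sulfonamide

A few compounds are considered here, and "the series" means these few. Any claim that something is new, unique, unknown or untested is made for them only; others in the source may bear on it.

Measured so far:
- compound 1, `CC(=O)SCC(=O)c1ccc(NS(=O)(=O)c2ccc(OC3CCCN(C)C3)cc2)nc1`, in a functional assay on U226 cells (Homo sapiens) for cytotoxicity (a lower number here means that less compound is needed, a higher number that more compound is needed for the effect), compound 1 gives 1200 nM
- compound 2, `COc1ccc(S(=O)(=O)Nc2ccc(C(=O)CSC(C)=O)cn2)cc1`, in this assay compound 2 gives "not determined" (no result reported)

Compound 2 shares its core with compound 1 and carries a plain methoxy group on the aryl ether oxygen, where compound 1 carries a ring-bearing substituent. Among the compounds with values here, for compound 2 the outcome in this assay is therefore not a number that can be placed on a scale: no single value stands against it, and no step between the two measured compounds can be drawn.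

Compound 3, `COCCCOc1ccc(S(=O)(=O)Nc2ccc(C(=O)CSC(C)=O)cn2)cc1`, differs from compound 2 in one place: 2-methoxyethyl in place of hydrogen on a saturated chain carbon bound to an oxygen on an aromatic ring. Within the data shown here, no measured pair in this assay follows a change of this kind, so the size of the step cannot be read off the data. With nothing pointing either way, the expectation is a change that stays within the usual scatter, with wide uncertainty in both directions. The estimate for compound 3 in this assay is 1500 nM, with a range from 400 nM to 6000 nM, anchored on compound 1 only because compound 1 gives 1200 nM in the same assay.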

Compound 3, half-maximal effective concentration: 29000 nM
For compound 3 the middle estimate is 19-fold (1.29 log units) below the measured one; the whole stated range lies below it.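

The group on the oxygen on an aromatic ring clearly matters in this assay: with 3-methoxypropyl in place of 1-methylpiperidin-3-yl, the data show a 24-fold higher number from compound 1 to compound 3 (1.38 log units; beyond the scatter), so much more of the open-chain compound is needed for the same effect. From the compounds shown here alone, compound 2 has no reported number, so the step from methoxy to 3-methoxypropoxy cannot be read, and the effect of lengthening the chain remains unknown. Nothing available here explains why the exchange of the ring-bearing group for the chain has a step of this size.

The single step changes the whole group at once, so the compounds shown cannot tell whether the difference follows the ring, its nitrogen or the methoxy end of the chain. An open chain ending in an amine, such as 3-(dimethylamino)propyl, would fall between compound 1 and compound 3 in structure, while a longer chain or one ending in a carboxylic acid would extend the comparison in other directions.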